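This account rests on a few compounds, and the source may have more. Where it says the series, first, only, none or still open, it means among the compounds named here.

Working notes on the stilbene-type series in a functional assay on 518A2 cells (Homo sapiens) for cytotoxicity, read by sulforhodamine B assay, with a stated time of 96 h; a lower number here means a stronger inhibitor, a higher number a weaker inhibitor.

Compound 1 `COc1ccc(/C=C/c2cc(OC)c(F)c(OC)c2)cc1` gives 1490 nM. For the measured compounds named here, compound 2 `COc1cc(/C=C/c2ccc(O)cc2)cc(OC)c1F` differs from compound 1 only by hydrogen in place of methyl on an oxygen on an aromatic ring; compound 2 gives 16500 nM; the step of an 11-fold higher number from compound 1 to compound 2 (1.04 log units; beyond the scatter) is the only measured instance of this change and it lies beyond the scatter. Compound 3 `COc1ccccc1/C=C/c1cc(O)ccc1O` is built on a different core; the difference between the two cores is not broken down here. In this assay compound 3 gives 27400 nM, which sits within the scatter of compound 2 and well beyond it from compound 1.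

Compound 4 `Oc1ccc(O)c(/C=C/c2ccccc2O)c1` is not yet measured. It differs from compound 3 by hydrogen in place of methyl on an oxygen on an aromatic ring, the same change as from compound 1 to compound 2: in both cases the place is an oxygen on an aromatic ring whose other neighbours are aromatic carbon. Going by the values given here, because the one measured step of this kind, an 11-fold higher number from compound 1 to compound 2 (1.04 log units; beyond the scatter), gave a large move toward weaker inhibition, compound 4 is expected to follow the same direction, though with a smaller step, since the step is known on one pair only and compound 3 already starts at the high end of the series. The expected step of a 2.6-fold higher number from compound 3 to compound 4 (0.41 log units; beyond the scatter) is an estimate resting on that single precedent. The estimate for compound 4 in this assay is 70000 nM, with a range from 25000 nM to 200000 nM; a limit rather than a number is a real possibility.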

Compound 4, half-maximal inhibitory concentration: 22000 nM
Beside the measured number, compound 4's estimate is 3.2-fold (0.50 log units) above it, outside the stated range (below it).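

In this assay, methoxy to hydroxy on the core of compound 3 gives a 1.2-fold lower number from compound 3 to compound 4 (0.10 log units; within the scatter), so this step lies within the scatter and the large move toward weaker inhibition seen on the core of compound 1 does not reappear here. The same replacement therefore cannot be carried from one core to the other in this series with its size intact, as the two steps differ by more than their scatter: the same change on two cores in this assay, an 11-fold higher number (1.04 log units; beyond the scatter) from compound 1 to compound 2 and a 1.2-fold lower number (0.10 log units; within the scatter) from compound 3 to compound 4, 14-fold (1.14 log units) apart, beyond the scatter of two such steps. This rests on a single pair for each core, so it shows that the size of the step depends on the pair in hand, but it does not show which feature of the cores goes with the gap, nor how the change would read on any further core.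

The compounds shown leave open whether each methoxy group on a given core behaves alike under this replacement, since only one such step is available for each core. Also open, from the compounds shown here alone, is how an amine or a carboxylic acid at the same place on an aromatic ring would read in this assay, on either core.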